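Swapping Cyclopropyl for Isopropyl on the Shared Core

A few compounds are considered here, and "the series" means these few. Any claim that something is new, unique, unknown or untested is made for them only; others in the source may bear on it.

Compound 3 `O=C(NCCCNc1nc(Nc2cccc(F)c2)ncc1C1CC1)C1CCC1` gives 8 nM in an assay on isolated protein for inhibition of serine/threonine-protein kinase TBK1 (Homo sapiens); a higher number here means a weaker inhibitor, a lower number a stronger inhibitor. Among the measured compounds shown here, that is the lowest of the three numbers measured so far, though compound 1 `O=C(NCCCNc1nc(Nc2cccnc2)ncc1C1CC1)C1CCC1` gives 13 nM in this assay and the step of a 1.6-fold lower number from compound 1 to compound 3 (0.21 log units; within the scatter) falls within the scatter, so these two cannot be told apart. Compound 2 `O=C(NCCCNc1nc(Nc2cncnc2)ncc1C1CC1)C1CCC1` gives 3200 nM in this assay; the steps of a 250-fold higher number from compound 1 to compound 2 (2.39 log units; beyond the scatter) and a 400-fold lower number from compound 2 to compound 3 (2.60 log units; beyond the scatter) are both large. All three measured steps concern only the group on the aromatic amine nitrogen.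

Compound 4 `CC(C)c1cnc(Nc2cccc(F)c2)nc1NCCCNC(=O)C1CCC1` differs from compound 3 at another place: isopropyl in place of cyclopropyl on an aromatic carbon, two atoms from the ring nitrogen and para to the (3-fluorophenyl)amino group. For the measured compounds named here, no measured step touches this position, so the record offers no direct guide for it. The expected step in this assay is a 1.5-fold higher number from compound 3 to compound 4 (0.18 log units; within the scatter), with no change beyond the scatter foreseen. Compound 4 is therefore expected to give 12 nM, within a range from 4 nM to 40 nM.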

Compound 4, half-maximal inhibitory concentration: > 1000 nM
Compound 4 ended at the assay's limit; the forecaster's own chance of this, stated with the estimate: 2%; middle value at least 83-fold (1.92 log units) away from the limit.
By their numbers in this assay, from the lowest: compounds 3 and 1 (each within the scatter of the next); then compound 2.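

Cyclopropyl and isopropyl each bring 3 heavy atoms, all carbon, and the only counted difference is the three-membered ring, yet this swap gives an at least 120-fold higher number from compound 3 to compound 4 (2.09 log units; beyond the scatter) in this assay on the shared core. For compound 4, the value > 1000 nM is a limit of the assay and not a number: the limit of > 1000 nM in this assay, at which 1 of the 4 values shown sits. Among the compounds shown here, the earlier steps all concerned the group on the aromatic amine nitrogen, so this is the first sign that the aromatic carbon para to the (3-fluorophenyl)amino group can also carry a large step.

The compounds shown leave open how other groups at this carbon, such as methyl, ethyl, cyclobutyl or an amine, would fare in this assay on this core. They also leave open whether isopropyl would bring a similar step with the pyridin-3-yl group of compound 1 on the amine nitrogen.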